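Methylcarbamoyl in place of hydrogen on compound 2

The source may report more compounds than this note shows. Statements on the series, on what has been measured and on what is new or still open speak of the compounds shown alone.

- compound 1 `CNC(=O)c1cc(C(=O)NCCCC2CNCCO2)cn(Cc2ccccc2)c1=O` gives >= 194 ug/mL as a limit of the assay
- compound 2 `CNC(=O)c1cccn(Cc2ccccc2)c1=O` gives 78 ug/mL as a measured number

Within the data shown here, in a physicochemical assay for solubility (on this read-out lower numbers stand for lower solubility and higher numbers for higher solubility), compound 2 stands at 78 ug/mL as the only number so far. Compound 3 `CNC(=O)c1cc(C(=O)NC)c(=O)n(Cc2ccccc2)c1` differs from compound 2 by methylcarbamoyl in place of hydrogen on an aromatic carbon in one place: methylcarbamoyl in place of hydrogen on an aromatic carbon. Among the measured compounds shown here, no measured step isolates this change. In this assay no step beyond the scatter is expected. The expected move is a 1.2-fold higher number from compound 2 to compound 3 (0.06 log units; within the scatter) and no more than that. For compound 3 the estimate is 90 ug/mL with an expected range from 30 ug/mL to 250 ug/mL for the coming measurement.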

Compound 3, solubility: >= 118 ug/mL
Compound 3 was reported as a limit (the forecaster's own chance of this, stated with the estimate: 15%); at least 1.3-fold (0.11 log units) between middle value and limit.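

In this assay methylcarbamoyl on this aromatic carbon gives an at least 1.5-fold higher number from compound 2 to compound 3 (0.17 log units; that floor lies within the scatter) and so the position carries the group with no drop in the number. How far the step goes stays unfixed, and its floor alone cannot be told from the scatter. Compound 3 stands only at a limit of the assay: the limit of >= 118 ug/mL in this assay, at which 1 of the 3 values shown sits.

The step between compound 1 and compound 3 cannot be read, since both values are limits. Going by these compounds, whether a carboxylic acid or a primary amine in place of the methylcarbamoyl on this carbon would give a measured number in this assay stays open.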